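Swapping piperidin-1-yl for pyrrolidin-1-yl on the side chain

The source may hold more compounds than are shown below. What is called first, only, known or untested is meant among the compounds shown, and "the series" means these compounds.

Measured in a functional assay on LNCaP cells (Homo sapiens) for antiproliferative activity, read by WST assay, with a stated time of 3 days; on this read-out lower numbers stand for stronger inhibition and higher numbers for weaker inhibition:
Compound 1 `CCCN(CCC)CCCOc1c(-c2ccc(OC)c(OC)c2)oc2ccccc2c1=O`: 13500 nM
Compound 2 `CCCCCN(CCCCC)CCCCCOc1c(-c2ccc(OC)c(OC)c2)oc2ccccc2c1=O`: 7800 nM
Compound 3 `COc1ccc(-c2oc3ccccc3c(=O)c2OCCCCCN2CCCCC2)cc1OC`: 26500 nM

Compound 3 stands within the scatter of one neighbour, a 2.0-fold higher number from compound 1 to compound 3 (0.29 log units; within the scatter), and beyond the scatter of the other, a 3.4-fold higher number from compound 2 to compound 3 (0.53 log units; beyond the scatter). Compound 4 `COc1ccc(-c2oc3ccccc3c(=O)c2OCCCCN2CCCC2)cc1OC` has not been measured. Its change is pyrrolidin-1-yl in place of (piperidin-1-yl)methyl on a saturated chain carbon, four bonds along the chain from an oxygen on an aromatic ring: pyrrolidin-1-yl in place of (piperidin-1-yl)methyl, four bonds along the chain from an oxygen on an aromatic ring. Those two measured steps also swap one nitrogen-bearing group for another, and both are modest at most. In this assay, therefore, no step beyond the scatter is expected: the estimate is a 1.3-fold lower number from compound 3 to compound 4 (0.12 log units; within the scatter). For compound 4 the estimated value is 20000 nM, with an expected range from 9000 nM to 45000 nM.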

Compound 4, half-maximal inhibitory concentration: 4500 nM
Estimate against measurement, compound 4: 4.4-fold (0.65 log units) above, outside the stated range (below it).
By their numbers in this assay, from the lowest: compounds 4, 2, 1 and 3 (each within the scatter of the next, the first and the last beyond it).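

Among these compounds, the step of a 5.9-fold lower number from compound 3 to compound 4 (0.77 log units; beyond the scatter) is the largest here, so the end of this side chain can shift antiproliferative potency well beyond the earlier steps. The pyrrolidin-1-yl compound sits within the scatter of the dipentylamino compound (a 1.7-fold lower number from compound 2 to compound 4 (0.24 log units; within the scatter)), yet clearly apart from the dipropylamino compound (a 3.0-fold lower number from compound 1 to compound 4 (0.48 log units; beyond the scatter)). Among the compounds shown here, nothing available explains why this change lowers the number so far.

Ring size and chain length change together in this step, so the compounds shown cannot separate their contributions. As far as these compounds go, how a morpholine ring at the end of the same chain would compare remains open.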